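Ether substituent series: working estimate for compound 4

The compounds below may be only part of what the source reports. "The series", "measured", "known", "first", "only" and "open" are said of these compounds alone.

Measured so far:
compound 1 `CCOc1ncc(-c2nc(C(F)(F)F)sc2N2CCN(C(=O)Cn3nc(C)nc3C)[C@H](C)C2)cn1` gives 364 nM in an assay on blood for inhibition of C-X-C chemokine receptor type 3 (Homo sapiens), with a stated time of 30 min; a lower number here means a stronger inhibitor, a higher number a weaker inhibitor
compound 2 `COc1ncc(-c2nc(C(F)(F)F)sc2N2CCN(C(=O)Cn3nc(C)nc3C)[C@H](C)C2)cn1` gives 1040 nM in this assay
compound 3 `Cc1nc(C)n(CC(=O)N2CCN(c3sc(C(F)(F)F)nc3-c3cnc(OC(C)C)nc3)C[C@H]2C)n1` gives 216 nM in this assay

Within the data shown here, compound 3 has the lowest number of the three, but only the step of a 4.8-fold lower number from compound 2 to compound 3 (0.68 log units; beyond the scatter) lies beyond the scatter; the step of a 1.7-fold lower number from compound 1 to compound 3 (0.23 log units; within the scatter) does not. Compound 4 `Cc1nc(C)n(CC(=O)N2CCN(c3sc(C(F)(F)F)nc3-c3cnc(OC4CCC4)nc3)C[C@H]2C)n1` is the next member: cyclobutyl in place of isopropyl on an oxygen on an aromatic ring. Among the measured compounds shown here, the steps that bear on it all sit on the same oxygen on an aromatic ring: a 2.9-fold higher number from compound 1 to compound 2 (0.46 log units; beyond the scatter) and a 4.8-fold lower number from compound 2 to compound 3 (0.68 log units; beyond the scatter), both modest, with the larger group at the lower number in each case. Cyclobutyl continues that direction by one carbon, so a small further fall in this assay, or none beyond the scatter, is expected: a 1.2-fold lower number from compound 3 to compound 4 (0.08 log units; within the scatter). Compound 4 is estimated at 180 nM, range 70 nM to 450 nM.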

Compound 4, half-maximal inhibitory concentration: 306 nM
Compound 4: middle estimate off by 1.7-fold (0.23 log units), on the low side; low and high end bracket the measured number.
By their numbers in this assay, from the lowest: compounds 3, 4 and 1 (each within the scatter of the next); then compound 2.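

In this assay, among these compounds, the cyclobutyl ring on this oxygen cannot be told apart from isopropyl (a 1.4-fold higher number from compound 3 to compound 4 (0.15 log units; within the scatter)) or from ethyl (a 1.2-fold lower number from compound 1 to compound 4 (0.08 log units; within the scatter)), so a four-membered ring here brings no separate step. Only methyl stands apart (a 3.4-fold lower number from compound 2 to compound 4 (0.53 log units; beyond the scatter)), leaving ethyl, isopropyl and cyclobutyl as one group that these numbers cannot order. No measurement at hand accounts for this.

Still open, on these data alone, is whether a longer chain such as butyl, or a larger ring such as cyclopentyl, stays in that group. As far as these compounds go, an amine in place of the ether is equally open.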